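The compounds below may be only part of what the source reports. "The series", "measured", "known", "first", "only" and "open" are said of these compounds alone.

Working notes on the series. Compound 1 `COCCOc1cc2oc(=O)n(CCC(=O)O)c2cc1Cl` is the weaker of the two measured compounds: in an assay on HEK293 cells for inhibition of kynurenine 3-monooxygenase (Homo sapiens), read by LC-MS, with a stated time of 20 h (on this read-out lower numbers stand for stronger inhibition and higher numbers for weaker inhibition), compound 1 gives 50100 nM, the highest number recorded here. Going by the values given here, compound 2 `Cc1ccc([C@@H](C)Oc2cc3onc(CCC(=O)O)c3cc2Cl)nc1` gives 1.59 nM in this assay, far below compound 1, well beyond the scatter; no single-point step links the two, so the pair only marks how wide the range in this assay already is.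

Compound 3 `O=C(O)CCn1c(=O)oc2cc(OCc3ccccn3)c(Cl)cc21` is the next compound for this assay. Its change from compound 1 is pyridin-2-yl in place of methoxymethyl on a saturated chain carbon bound to an oxygen on an aromatic ring.

Among the compounds with values here, no step between measured compounds is available for this change. Given that compound 1 sits at 50100 nM and compound 2 reaches 1.59 nM, a sizeable drop is expected for compound 3, with the step of a 63-fold lower number from compound 1 to compound 3 (1.80 log units; beyond the scatter) estimated to lie well beyond the scatter. Compound 3 is expected near 800 nM, in a range from 60 nM to 10000 nM.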

Compound 3, half-maximal inhibitory concentration: 5010 nM
Compound 3: the middle estimate sits 6.3-fold (0.80 log units) below what was measured; measured number inside the range.
By their numbers in this assay, from the lowest: compound 2; then compound 3; then compound 1.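

In this assay, going by these compounds alone, the group on this saturated chain carbon does affect the read-out on the shared core: pyridin-2-yl in place of methoxymethyl gives a 10-fold lower number from compound 1 to compound 3 (1.00 log units; beyond the scatter) as the first single-place step. The step comes with a six-membered aromatic ring entering and with the counts of hydrogen-bond donors and acceptors unchanged, although a single pair cannot separate the ring from the other differences between the two groups. Nothing on hand bears on why the number falls.

The compounds shown leave open whether phenyl, which has carbon in place of the ring nitrogen, or pyridin-3-yl would give a similar number at this place. On these data alone, it also remains open how a longer chain, such as (pyridin-2-yl)ethyl in place of (pyridin-2-yl)methyl, would read.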